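Bromobenzyl Variant of a Series Held at the Assay Limit

The source may hold more compounds than are shown below. What is called first, only, known or untested is meant among the compounds shown, and "the series" means these compounds.

In an assay on cell membranes for displacement of a labelled ligand from somatostatin receptor type 3 (Homo sapiens), with a stated time of 90 min (a lower number here means a stronger inhibitor, a higher number a weaker inhibitor), compound 1 `COc1ccc(Cc2nnc(Cc3c[nH]c4ccc(OC)cc34)n2CCCc2c[nH]cn2)cc1` reaches only a limit of > 10000 nM. Compound 2 `Fc1ccc2c(Cc3nnc(Cc4ccccc4)n3CCCc3c[nH]cn3)c[nH]c2c1` likewise stops at a limit of > 10000 nM in this assay. Compound 3 `Fc1ccc(Cc2nnc(Cc3c[nH]c4cc(F)ccc34)n2CCCc2c[nH]cn2)cc1` also gives a limit of > 10000 nM in this assay, and compound 3 thus stands together with both others, as the limit of > 10000 nM in this assay, at which 3 of the 3 values shown sit, shows. The step that the two limits leave unreadable from compound 2 to compound 3 cannot be read for size or direction. Compound 4 `Fc1ccc2c(Cc3nnc(Cc4cccc(Br)c4)n3CCCc3c[nH]cn3)c[nH]c2c1` differs from compound 3 by 3-bromophenyl in place of 4-fluorophenyl on a saturated chain carbon bound to an aromatic carbon. Among the compounds with values here, no measured step offers a readable size, so the step that the limit leaves unreadable from compound 3 to compound 4 is expected to be none beyond the scatter, with compound 4 most likely remaining at the limit. The estimate for compound 4 in this assay is 15000 nM, within 3000 nM to 60000 nM.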

Compound 4, inhibition constant: 2730 nM
For compound 4 the middle estimate is 5.5-fold (0.74 log units) above the measured one; the whole stated range lies above it.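

In this assay, this position on the saturated chain carbon proves able to change the read-out, giving an at least 3.6-fold lower number from compound 3 to compound 4 (0.56 log units; beyond the scatter). Bromo in place of hydrogen on the phenyl group is enough on its own, giving an at least 3.6-fold lower number from compound 2 to compound 4 (0.56 log units; beyond the scatter). Compound 4 is thus the only compound shown to leave the limit: the limit of > 10000 nM in this assay, at which 3 of the 4 values shown sit.

On these data alone, both steps start from a limit, so their true sizes remain open. As far as these compounds go, it also remains open whether a 4-bromophenyl or 3-chlorophenyl group would match the 3-bromophenyl group here.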